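The source may report more compounds than this note shows. Statements on the series, on what has been measured and on what is new or still open speak of the compounds shown alone.

In an ADME assay on BaF3 cells (Mus musculus) for cytotoxicity (on this read-out lower numbers stand for an effect already at smaller amounts and higher numbers for an effect only at larger amounts of compound), compound 1 `CN1CCN(C(=O)c2cc3c(Nc4ccc(OC(F)(F)F)cc4)ncnc3s2)CC1` gives 2690 nM. Compound 2 `COc1ccc(Nc2cc(-c3ccncc3)ncn2)cc1` reaches only a limit of this assay, > 10000 nM, so no number is known for it. Compound 3 `FC(F)(F)Oc1ccc(Nc2ncnc3nn(Cc4cccnc4)cc23)cc1` likewise stops at a limit, > 10000 nM. Compound 2 therefore stands at the limit of > 10000 nM in this assay, at which 2 of the 3 values shown sit, while compound 1 alone gives a number. Compound 4 `Fc1ccc(Nc2cc(-c3ccncc3)ncn2)cc1` has not yet been measured in this assay; it differs from compound 2 by fluoro in place of methoxy on an aromatic carbon. Among the measured compounds shown here, no pair of measured compounds shows a change of this kind, so no measured step guides the expectation. Compound 4 is expected to stay close to compound 2, an estimated step that the limit leaves unreadable from compound 2 to compound 4 within the usual scatter. Compound 4 is estimated at 15000 nM, between 5000 nM and 50000 nM, most likely again reported only as a limit.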

Compound 4, half-maximal effective concentration: > 10000 nM
Compound 4: a limit, no number; the forecaster's own chance of this, stated with the estimate: 70%; the middle value does not contradict the limit.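

Compound 2 and compound 4 both stop at a limit in this assay, so no step can be read between them. The compounds shown leave open what number either would give, and whether fluoro in place of methoxy changes the read-out at all.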